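The source may hold more compounds than are shown below. What is called first, only, known or untested is meant among the compounds shown, and "the series" means these compounds.

Measured in an assay on Sf9 cells for inhibition of receptor-interacting serine/threonine-protein kinase 3 (Homo sapiens), read by luminescence and 33P incorporation, with a stated time of 30 min, in the presence of a further agent that is not named here; on this read-out higher numbers stand for weaker inhibition and lower numbers for stronger inhibition:
compound 1 `CN1CCN(c2ccc3nc(-c4cccc5ccccc45)c(-c4ccncc4)n3n2)CC1` — 880 nM
compound 2 `CN1CCN(c2ccc3nc(-c4cccc(-c5cccs5)c4)c(-c4ccncc4)n3n2)CC1` — 270 nM

Compound 2 holds the lowest of the two numbers in this assay; compound 1 stands above it, a 3.3-fold lower number from compound 1 to compound 2 (0.51 log units; beyond the scatter). Compound 3 `CN1CCN(c2ccc3nc(-c4cccc(-c5ccsc5)c4)c(-c4ccncc4)n3n2)CC1` differs from compound 2 by thiophen-3-yl in place of thiophen-2-yl on an aromatic carbon. Among the compounds with values here, no measured step covers this kind of change; the single known step, a 3.3-fold lower number from compound 1 to compound 2 (0.51 log units; beyond the scatter), concerns a different replacement and gives no direct guide. With nothing to point either way, no step beyond the scatter is expected in this assay. Compound 3 is therefore estimated at 280 nM (range 100 nM to 800 nM), corresponding to an expected 1.0-fold higher number from compound 2 to compound 3 (0.02 log units; within the scatter).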

Compound 3, half-maximal inhibitory concentration in the receptor-interacting serine/threonine-protein kinase 3 assay: 300 nM
Estimate against measurement, compound 3: 1.1-fold (0.03 log units) below; the measured number falls inside the stated range.
By their numbers in the receptor-interacting serine/threonine-protein kinase 3 assay, from the lowest: compounds 2 and 3 (each within the scatter of the next); then compound 1.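

In the receptor-interacting serine/threonine-protein kinase 3 assay the replacement of thiophen-2-yl by thiophen-3-yl gives a 1.1-fold higher number from compound 2 to compound 3 (0.05 log units; within the scatter) and so this position takes either thiophene attachment. In the receptor-interacting serine/threonine-protein kinase 3 assay the 3-(thiophen-3-yl)phenyl group gives a 2.9-fold lower number from compound 1 to compound 3 (0.47 log units; beyond the scatter) and so the difference from naphthalen-1-yl is not tied to one thiophene attachment. In a physicochemical assay for lipophilicity (on this read-out lower numbers stand for lower lipophilicity and higher numbers for higher lipophilicity), the same thiophene replacement gives no change at the digits printed from compound 2 to compound 3 (within the scatter) and leaves the two compounds level. In the physicochemical assay compound 2 reads 5 and compound 3 reads 5 on the same scale.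

From the compounds shown here alone, how a furan-3-yl or pyridin-3-yl group in place of thiophen-3-yl would read in the receptor-interacting serine/threonine-protein kinase 3 assay stays open. No measured evidence bears on these results.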